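A few compounds are considered here, and "the series" means these few. Any claim that something is new, unique, unknown or untested is made for them only; others in the source may bear on it.

Measured so far in a functional assay on RAW264.7 cells (Mus musculus) for inhibition, read by Griess assay, with stated times of 2 h and 24 h; a lower number here means a stronger inhibitor, a higher number a weaker inhibitor:
compound 1 `COc1ccc([C@@H]2CC(=O)c3c(O)cc(OCc4cn(Cc5ccc(C(F)(F)F)cc5)nn4)cc3O2)cc1O` — 17700 nM
compound 2 `COc1ccc([C@@H]2CC(=O)c3c(O)cc(OCc4cn(Cc5ccccc5)nn4)cc3O2)cc1O` — 11000 nM
compound 3 `C=CCn1cc(COc2cc(O)c3c(c2)O[C@H](c2ccc(OC)c(O)c2)CC3=O)nn1` — 13800 nM

The three compounds share one core and differ only in the group on the saturated chain carbon bound to the aromatic nitrogen. Compound 3 sits second highest of the three numbers; its nearest neighbour is compound 2, by a 1.3-fold higher number from compound 2 to compound 3 (0.10 log units; within the scatter), and its furthest is compound 1, by a 1.3-fold lower number from compound 1 to compound 3 (0.11 log units; within the scatter). Both gaps lie within the scatter, so the three values are not separated.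

The next compound is compound 4 `COc1ccc([C@@H]2CC(=O)c3c(O)cc(OCc4cn(Cc5cccc(C#N)c5)nn4)cc3O2)cc1O`. Relative to compound 3 the change is 3-cyanophenyl in place of vinyl on a saturated chain carbon bound to an aromatic nitrogen; cut one bond further out it reads allyl to 3-cyanobenzyl.

Going by the values given here, three measured steps bear on this. Replacing phenyl by vinyl gave a 1.3-fold higher number from compound 2 to compound 3 (0.10 log units; within the scatter); replacing 4-(trifluoromethyl)phenyl by vinyl gave a 1.3-fold lower number from compound 1 to compound 3 (0.11 log units; within the scatter); and exchanging trifluoromethyl for hydrogen on the aromatic ring gave a 1.6-fold lower number from compound 1 to compound 2 (0.21 log units; within the scatter). None of these leaves the scatter, so putting a substituted phenyl back in place of vinyl is expected to move this assay by no more than the scatter, in no assignable direction: the expected step is a 1.1-fold lower number from compound 3 to compound 4 (0.03 log units; within the scatter). Compound 4 is accordingly estimated at 13000 nM, with a range from 6000 nM to 30000 nM.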

Compound 4, half-maximal inhibitory concentration: 18000 nM
Beside the measured number, compound 4's estimate is 1.4-fold (0.14 log units) below it; the range from low to high includes it.
By their numbers in this assay, from the lowest: compounds 2, 3, 1 and 4 (each within the scatter of the next).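

In this assay, exchanging allyl for 3-cyanobenzyl at this position gives a 1.3-fold higher number from compound 3 to compound 4 (0.12 log units; within the scatter), so a group with an aromatic ring and a nitrile, bringing one hydrogen-bond acceptor, is not separated from the small allyl group. Adding cyano to the unsubstituted benzyl group gives a 1.6-fold higher number from compound 2 to compound 4 (0.21 log units; within the scatter), and exchanging 4-(trifluoromethyl)phenyl for 3-cyanophenyl gives a 1.0-fold higher number from compound 1 to compound 4 (0.01 log units; within the scatter), so neither substituent on the phenyl ring is separated from the other or from hydrogen, and all four groups on the saturated chain carbon bound to the aromatic nitrogen now lie within the scatter of one another. No measured evidence accounts for this flat picture.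

Still open, from the compounds shown here alone, is whether a group of a different kind at this position, such as a primary amine, a carboxylic acid or a longer alkyl chain, would move the number in this assay beyond the scatter. The compounds shown also leave open whether a change elsewhere on the shared core, such as replacing the free phenolic hydroxyl with a methoxy group, would have a larger effect than any change at this position.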